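From Trifluoromethyl to Chloro: Expecting Little Change

The compounds below may be only part of what the source reports. "The series", "measured", "known", "first", "only" and "open" are said of these compounds alone.

In a functional assay on SW-620 cells (Homo sapiens) for inhibition, read by MTT assay, with a stated time of 72 h (on this read-out higher numbers stand for weaker inhibition and lower numbers for stronger inhibition), compound 1 `COc1cc(NC(C)CCCNC(=O)Nc2ccc(F)cc2)c2ncccc2c1` gives 25000 nM and compound 2 `COc1cc(NC(C)CCCNC(=O)Nc2ccc(C(F)(F)F)cc2)c2ncccc2c1` gives 22000 nM as its value. Going by the values given here, these two numbers lie within the usual scatter of each other, so compound 2 stands level with compound 1, the only other compound measured so far.

Compound 3 `COc1cc(NC(C)CCCNC(=O)Nc2ccc(Cl)cc2)c2ncccc2c1` has not been measured yet. It differs from compound 2 in one place (chloro in place of trifluoromethyl on an aromatic carbon): chloro in place of trifluoromethyl on an aromatic carbon, para to a large group.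

Among the compounds with values here, one measured step bears on this change, trifluoromethyl in place of fluoro on an aromatic carbon. Within the data shown here, with a 1.1-fold lower number from compound 1 to compound 2 (0.06 log units; within the scatter) as the only guide, no step beyond the scatter is expected in this assay in either direction. Among the measured compounds shown here, this is thin evidence, since it is a single pair and no chloro compound has a measured value so far. The estimated step is a 1.0-fold higher number from compound 2 to compound 3 (0.02 log units; within the scatter) and no larger shift is foreseen. For compound 3 the expected value is 23000 nM, with an estimated range from 10000 nM to 45000 nM.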

Compound 3, half-maximal inhibitory concentration: 28000 nM
The estimate for compound 3 lay 1.2-fold (0.09 log units) below the measured number; low and high end bracket the measured number.
By their numbers in this assay, from the lowest: compounds 2, 1 and 3 (each within the scatter of the next).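

In this assay, chloro in place of trifluoromethyl gives a 1.3-fold higher number from compound 2 to compound 3 (0.10 log units; within the scatter) and chloro in place of fluoro gives a 1.1-fold higher number from compound 1 to compound 3 (0.05 log units; within the scatter). Going by these compounds alone, until now only one pair spoke for this position on the aromatic ring; compound 3 adds a third group and so closes a set of three comparisons, and none of them leaves the scatter. Even the exchange of the trifluoromethyl group, with its four heavy atoms, for a single chlorine atom makes no readable difference, so fluoro, chloro and trifluoromethyl stand level here and no order can be drawn among compounds 1, 2 and 3. The data shown offer nothing that could explain this flat result.

All three groups shown at this position carry no hydrogen-bond donors or acceptors, so it remains open whether an amine or a carboxylic acid in the same place would shift the number beyond the scatter. Also open, going by these compounds, is whether this insensitivity would hold on a compound with a longer chain, since the chain and the shared core stay the same throughout these three compounds.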